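Three Close Values and a Fluorinated Neighbour

The source may report more compounds than this note shows. Statements on the series, on what has been measured and on what is new or still open speak of the compounds shown alone.

Compound 1 `COC1=C(C)C(=O)/C(=C(O)/C=C/c2ccc(Br)cc2)C(=O)C1(C)C`: 1.9 ug/mL
Compound 2 `COC1=C(C)C(=O)/C(=C(O)/C=C/c2cccc(OC)c2)C(=O)C1(C)C`: 2.4 ug/mL
Compound 3 `COC1=C(C)C(=O)/C(=C(O)/C=C/c2ccccc2OC)C(=O)C1(C)C`: 2.8 ug/mL

These values come from a functional assay on KB cells (Homo sapiens) for cytotoxicity; a lower number here means that less compound is needed, a higher number that more compound is needed for the effect. Compound 3 lies within the scatter of both other compounds, as the two steps that reach it show: a 1.2-fold higher number from compound 2 to compound 3 (0.07 log units; within the scatter), and a 1.5-fold higher number from compound 1 to compound 3 (0.17 log units; within the scatter). The three compounds therefore cannot be ranked.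

Compound 4 `COC1=C(C)C(=O)/C(=C(O)/C=C/c2ccc(F)cc2)C(=O)C1(C)C` keeps the shared core and alters one group: 4-fluorophenyl in place of 2-methoxyphenyl on a double-bonded chain carbon bound to a double-bonded chain carbon. All three measured steps exchange this same group. Besides the two above, there is a 1.3-fold higher number from compound 1 to compound 2 (0.10 log units; within the scatter), and this one is also small. For the measured compounds named here, none of the measured compounds carries 4-fluorophenyl, although the 4-bromophenyl of compound 1 is the closest match by name. With so little movement among these groups, no change beyond the scatter is expected in this assay. The expected size of the change is a 1.2-fold lower number from compound 3 to compound 4 (0.09 log units; within the scatter). Compound 4 is estimated at 2.3 ug/mL, with an expected range from 1.3 ug/mL to 4 ug/mL.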

Compound 4, concentration for half-maximal effect: 2.7 ug/mL
Estimate against measurement, compound 4: 1.2-fold (0.07 log units) below; measured number inside the range.
By their numbers in this assay, from the lowest: compounds 1, 2, 4 and 3 (each within the scatter of the next).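

In this assay the new group on a double-bonded chain carbon bound to a double-bonded chain carbon stays within the scatter of all three earlier compounds (a 1.0-fold lower number from compound 3 to compound 4 (0.02 log units; within the scatter)) and (a 1.1-fold higher number from compound 2 to compound 4 (0.05 log units; within the scatter)) and (a 1.4-fold higher number from compound 1 to compound 4 (0.15 log units; within the scatter)). For the compounds shown here, the last of these steps adds something new, as it is the only one that exchanges just fluoro for bromo on an aromatic carbon, and this small exchange also leaves the number within the scatter. Nothing available here accounts for how closely these four compounds agree.

The compounds shown leave open whether an amine or a carboxylic acid on this phenyl ring would move the number beyond the scatter. They also leave open whether a longer chain in place of the phenyl ring would do so.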